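A few compounds are considered here, and "the series" means these few. Any claim that something is new, unique, unknown or untested is made for them only; others in the source may bear on it.

Compound 1 `CCOC(=O)c1oc2ccc(NS(=O)(=O)c3cccc(C)c3)cc2c1C`: in a functional assay on MCF7 cells (Homo sapiens) for antiproliferative activity, read by MTT assay, with a stated time of 72 h (on this read-out lower numbers stand for stronger inhibition and higher numbers for weaker inhibition), compound 1 gives 101000 nM.
Compound 2 `CCOC(=O)c1oc2ccc(NS(=O)(=O)c3ccc(Cl)cc3)cc2c1C`: in this assay compound 2 gives 81200 nM.
Compound 3 `CCOC(=O)c1oc2ccc(NS(=O)(=O)c3cccc(Cl)c3)cc2c1C`: in this assay compound 3 gives 83900 nM.

Compound 1 carries the largest of the three numbers, yet its separation from the other two is slight: a 1.2-fold lower number from compound 1 to compound 2 (0.09 log units; within the scatter) and a 1.2-fold lower number from compound 1 to compound 3 (0.08 log units; within the scatter) are both within the scatter, and a 1.0-fold higher number from compound 2 to compound 3 (0.01 log units; within the scatter) as well, so the three compounds cannot be told apart on these data.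

Compound 4 `CCOC(=O)c1oc2ccc(NS(=O)(=O)c3cccc([N+](=O)[O-])c3)cc2c1C` has not yet been measured in this assay. It differs from compound 1 in one place: nitro in place of methyl on an aromatic carbon.

Within the data shown here, every measured step so far concerns a swap of the small group on the six-membered aromatic ring that sits on the sulfonyl sulfur, and none of those swaps moved the number beyond the scatter. Among the measured compounds shown here, a nitro group at that place has no measured precedent, so the expectation rests on the pattern that changes on this ring have so far been silent. The step from compound 1 to compound 4 is therefore expected to be small, about a 1.1-fold lower number from compound 1 to compound 4 (0.05 log units; within the scatter), with no clear direction. The estimate for compound 4 in this assay is 90000 nM, expected to fall between 40000 nM and 200000 nM.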

Compound 4, half-maximal inhibitory concentration: 74800 nM
Compound 4: middle estimate off by 1.2-fold (0.08 log units), on the high side; the measured number falls inside the stated range.
By their numbers in this assay, from the lowest: compounds 4, 2, 3 and 1 (each within the scatter of the next).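

Among the compounds shown, 3-nitrophenyl is the only group on this ring that carries hydrogen-bond acceptors, and it is also larger than methyl by heavy-atom count, yet in this assay the swap gives a 1.4-fold lower number from compound 1 to compound 4 (0.13 log units; within the scatter) and so leaves the read-out unresolved from that of compound 1. The same holds against the two chlorinated compounds, with a 1.1-fold lower number from compound 3 to compound 4 (0.05 log units; within the scatter) and a 1.1-fold lower number from compound 2 to compound 4 (0.04 log units; within the scatter), so this place now tolerates a wider range of groups without a change that can be told from the scatter, though only across these four compounds. No measurement on these compounds offers an explanation for this flat result.

Still open, from the compounds shown here alone, is whether any group at this place can move the number beyond the scatter, for example an amine or a carboxylic acid on the ring, or 4-nitrophenyl in place of 3-nitrophenyl. Going by these compounds, all four compounds also share the same core and ethyl ester, so it remains unknown whether a carboxylic acid or an amide at the ester, rather than a new group on this ring, would shift the read-out.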